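Aryl hydrazone variation on a shared bromophenyl core

The source may report more compounds than this note shows. Statements on the series, on what has been measured and on what is new or still open speak of the compounds shown alone.

Measured so far:
compound 1, `O=C(Cc1csc2nc(-c3ccc(Br)cc3)cn12)N/N=C/c1ccccc1`: 91200 nM
compound 2, `O=C(Cc1csc2nc(-c3ccc(Br)cc3)cn12)N/N=C/c1ccccc1O`: 12900 nM
compound 3, `COc1cccc(OC)c1/C=N/NC(=O)Cc1csc2nc(-c3ccc(Br)cc3)cn12`: 47900 nM

The three compounds share one core and differ only in the aryl group on the carbon with a double bond to nitrogen. In a functional assay on LOX IMVI cells (Homo sapiens) for inhibition, read by sulforhodamine B assay, with a stated time of 48 h (on this read-out higher numbers stand for weaker inhibition of growth and lower numbers for stronger inhibition of growth), compound 3 gives 47900 nM, the second highest of the three numbers. Its nearest neighbour is compound 1, separated by a 1.9-fold lower number from compound 1 to compound 3 (0.28 log units; within the scatter); its furthest is compound 2, separated by a 3.7-fold higher number from compound 2 to compound 3 (0.57 log units; beyond the scatter). Within the data shown here, the one substantial step in the set is a 7.1-fold lower number from compound 1 to compound 2 (0.85 log units; beyond the scatter).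

Compound 4, `O=C(Cc1csc2nc(-c3ccc(Br)cc3)cn12)N/N=C/c1ccc(Cl)cc1Cl`, is not yet measured. It differs from compound 3 as follows: 2,4-dichlorophenyl in place of 2,6-dimethoxyphenyl on a carbon with a double bond to nitrogen. Among the measured compounds shown here, no measured step introduces chlorine on this ring, so the relevant precedents are only indirect. The step from compound 1 to compound 3 shows that two methoxy groups leave the number essentially where it was, and the step from compound 1 to compound 2 shows that a hydroxy is what moved it. Compound 4 carries neither, so its number is expected to stay close to that of compound 3, with a step of a 1.4-fold lower number from compound 3 to compound 4 (0.14 log units; within the scatter), inside the scatter. The estimate for compound 4 in this assay is 35000 nM, with a range from 12000 nM to 100000 nM.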

Compound 4, concentration for total growth inhibition: 49000 nM
Estimate against measurement, compound 4: 1.4-fold (0.15 log units) below, within the range that was stated.
By their numbers in this assay, from the lowest: compound 2; then compounds 3, 4 and 1 (each within the scatter of the next).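

In this assay, 2,4-dichlorophenyl and 2,6-dimethoxyphenyl on the carbon with a double bond to nitrogen cannot be told apart, with a 1.0-fold higher number from compound 3 to compound 4 (0.01 log units; within the scatter), and the same holds against plain phenyl, with a 1.9-fold lower number from compound 1 to compound 4 (0.27 log units; within the scatter). Chlorine on this ring is new to the series, and it joins the two methoxy groups in reading alike with the unsubstituted ring, leaving the 2-hydroxyphenyl of compound 2 as the only aryl group here set apart, with a 3.8-fold higher number from compound 2 to compound 4 (0.58 log units; beyond the scatter). Nothing measured bears on why these aryl groups read as they do, or on what sets compound 2 apart.

As far as these compounds go, the separate reading of compound 2 still rests on a single compound, and whether an amine or a carboxylic acid on this ring would read with compound 2 or with compounds 1, 3 and 4 remains open. Also open, from the compounds shown here alone, is whether a saturated cyclohexyl group in place of the aryl group would keep the number in this range, and how any of these changes would read on a core without the bromine.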